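The source may hold more compounds than are shown below. What is called first, only, known or untested is meant among the compounds shown, and "the series" means these compounds.

Measured compounds:
Compound 1, `CC(C)c1noc(N2CCC(Oc3cc(N4CCc5cc(N6CCCCC6=O)ccc54)ncn3)CC2)n1`, gives 3.8 in a physicochemical assay for lipophilicity, measured as octanol-water partition, at pH 7.4; on this read-out higher numbers stand for higher lipophilicity and lower numbers for lower lipophilicity.
Compound 2, `CC(C)c1noc(N2CCC(Oc3cc(N4CCc5cc(S(C)(=O)=O)ccc54)ncn3)CC2)n1`, gives 3.1 in this assay.
Compound 3, `CCc1cnc(N2CCC(C(C)COC(=O)N3CCc4cc(S(C)(=O)=O)cc(F)c43)CC2)nc1`, gives 3.6 in this assay.

Compound 2 stands lowest of the three numbers; compound 3 lies nearest to it and compound 1 furthest, both beyond the scatter. Compound 4, `CC(C)c1noc(N2CCC(Oc3cc(N4CCc5cc(N6CCOCC6=O)ccc54)ncn3)CC2)n1`, has not yet been measured in this assay. It differs from compound 2 in one place: 3-oxomorpholin-4-yl in place of methylsulfonyl on an aromatic carbon. Going by the values given here, the one measured step that bears on this position is a number 0.70 log units lower from compound 1 to compound 2 (beyond the scatter), where a ring of similar size left and methylsulfonyl entered. The change to compound 4 runs the other way, methylsulfonyl leaving and a six-membered ring with 2 hetero atoms entering, so a step upward is expected, though smaller than that one. The expected step is a number 0.20 log units higher from compound 2 to compound 4 (within the scatter). For compound 4 the estimate is 3.3, with a range from 2.9 to 3.7.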

Compound 4, distribution coefficient: 3.1
The estimate for compound 4 lay 0.20 log units above the measured number; the measured number falls inside the stated range.
By their numbers in this assay, from the lowest: compounds 2 and 4 (each within the scatter of the next); then compounds 3 and 1 (each within the scatter of the next).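

In this assay, 3-oxomorpholin-4-yl in place of methylsulfonyl on this aromatic carbon gives no change at the digits printed from compound 2 to compound 4 (within the scatter) and thus shows that a group with a six-membered non-aromatic ring can stand here and read the same as one with no ring. Replacing 2-oxopiperidin-1-yl with 3-oxomorpholin-4-yl gives a number 0.70 log units lower from compound 1 to compound 4 (beyond the scatter) and matches in size the earlier a number 0.70 log units lower from compound 1 to compound 2 (beyond the scatter) at this position. The higher number of compound 1 therefore does not follow from the presence of a six-membered ring at this place alone, since the ring of compound 4 differs from it in one ring atom.

As far as these compounds go, whether an amine or a carboxylic acid on this aromatic carbon would read like compound 2 and compound 4 remains open, as does whether 3-oxomorpholin-4-yl would behave the same way in place of methylsulfonyl on the core of compound 3. Nothing available accounts for the match between compound 2 and compound 4.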